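Replacing naphthalen-1-yl with 3,4-dimethoxyphenyl in compound 1

A few compounds are considered here, and "the series" means these few. Any claim that something is new, unique, unknown or untested is made for them only; others in the source may bear on it.

Of the compounds shown here, three have been read so far in a functional assay on COLO 205 cells (Homo sapiens) for cytotoxicity, read by sulforhodamine B assay, with a stated time of 48 h; a lower number here means a stronger inhibitor, a higher number a weaker inhibitor. Compound 1 `COc1cc(/C=C/C(=O)/C=C/c2cccc3ccccc23)ccc1OCc1cn(CCCOc2cc(=O)oc3ccccc23)nn1` gives 12700 nM, compound 2 `COc1cccc(/C=C/C(=O)/C=C/c2ccc(OCc3cn(CCOc4cc(=O)oc5ccccc45)nn3)c(OC)c2)c1` gives 11900 nM and compound 3 `COc1ccc(/C=C/C(=O)/C=C/c2ccc(OCc3cn(CCOc4cc(=O)oc5ccccc45)nn3)c(OC)c2)cc1OC` gives 6780 nM. All three values lie within the scatter of one another, so compound 1 cannot be ranked against compound 2 or compound 3.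

The step under consideration leads from compound 1 to compound 4 `COc1ccc(/C=C/C(=O)/C=C/c2ccc(OCc3cn(CCCOc4cc(=O)oc5ccccc45)nn3)c(OC)c2)cc1OC`: 3,4-dimethoxyphenyl in place of naphthalen-1-yl on a double-bonded chain carbon bound to a double-bonded chain carbon. Here 3,4-dimethoxyphenyl comes in place of naphthalen-1-yl on a double-bonded chain carbon bound to a double-bonded chain carbon.

Going by the values given here, no measured step makes this exact exchange. Among the compounds with values here, the only measured step is a 1.8-fold lower number from compound 2 to compound 3 (0.24 log units; within the scatter), with methoxy in place of hydrogen on an aromatic carbon, and it gives no clear shift. Compound 3 also carries 3,4-dimethoxyphenyl and gives 6780 nM, a value within the scatter of that of compound 1.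

No change beyond the scatter is therefore expected in this assay. The expected step is a 1.4-fold lower number from compound 1 to compound 4 (0.15 log units; within the scatter), which is estimated to stay within the scatter. For compound 4 the estimated value is 9000 nM, with an expected range of 4500 nM to 17000 nM.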

Compound 4, half-maximal inhibitory concentration: 13000 nM
For compound 4 the middle estimate is 1.4-fold (0.16 log units) below the measured one; low and high end bracket the measured number.
By their numbers in this assay, from the lowest: compounds 3, 2, 1 and 4 (each within the scatter of the next).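

In this assay, the exchange of naphthalen-1-yl for 3,4-dimethoxyphenyl on a double-bonded chain carbon bound to a double-bonded chain carbon can now be read directly, and it gives a 1.0-fold higher number from compound 1 to compound 4 (0.01 log units; within the scatter). One six-membered aromatic ring of carbon only is lost and hydrogen-bond acceptors enter with the heavy-atom count unchanged, yet in this pair the two groups cannot be told apart in this assay. No measurement on hand bears on this result.

On these data alone, whether a group of another kind at this position, such as an amine or a carboxylic acid, would move the number beyond the scatter remains open. This single pair also leaves open whether the same exchange would read alike on the linking chain of compound 3, where the naphthalen-1-yl counterpart is not among the compounds shown.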